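The source may hold more compounds than are shown below. What is called first, only, known or untested is meant among the compounds shown, and "the series" means these compounds.

Measured compounds in an ADME assay on MDCK cells (Canis lupus familiaris) for cytotoxicity, read by MTT assay, with a stated time of 3 days; a lower number here means that less compound is tolerated, a higher number that more compound is tolerated:
- compound 1 `CC1(C)C[C@H](O)C[C@](C)(CNc2ncc3ccccc3n2)C1`: 26700 nM
- compound 2 `CC1(C)C[C@H](O)C[C@](C)(CNc2cccc(S(N)(=O)=O)c2)C1`: > 100000 nM, which is a limit of this assay rather than a number
- compound 3 `Cc1ccc(NC[C@@]2(C)C[C@@H](O)CC(C)(C)C2)cc1S(N)(=O)=O`: 81500 nM

Compound 3 has the highest of the two numbers given, with compound 1 nearest below it, a gap beyond the scatter. Compound 4 `COc1ccc(NC[C@@]2(C)C[C@@H](O)CC(C)(C)C2)cc1S(N)(=O)=O` differs from compound 3 by methoxy in place of methyl on an aromatic carbon. For the measured compounds named here, the only measured step on the same ring is an at least 1.2-fold lower number from compound 2 to compound 3 (0.08 log units; that floor lies within the scatter), where one value is a limit (the limit of > 100000 nM in this assay, at which 1 of the 3 values shown sits), so little direction can be read from it. A small exchange at this position is therefore expected to move the number little, if at all, beyond the scatter. Compound 4 is expected to give about 90000 nM, between 40000 nM and 200000 nM, a step of a 1.1-fold higher number from compound 3 to compound 4 (0.04 log units; within the scatter).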

Compound 4, half-maximal cytotoxic concentration: > 100000 nM
Compound 4: only a limit was reported; the forecaster's own chance of this, stated with the estimate: 40%; middle value at least 1.1-fold (0.04 log units) from the limit.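

In this assay compound 4 gives > 100000 nM as a limit, not a number. Methoxy in place of methyl gives an at least 1.2-fold higher number from compound 3 to compound 4 (0.08 log units; that floor lies within the scatter) on this aromatic carbon, ortho to a sulfamoyl group, so the added oxygen brings no fall in the number here. The step between compound 2 and compound 4 cannot be read, and the true size of any rise stays hidden: the limit of > 100000 nM in this assay, at which 2 of the 4 values shown sit.

On these data alone, whether an amine or a carboxylic acid on this carbon would lower the number remains open. So does the effect of a longer chain such as ethoxy.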